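A few compounds are considered here, and "the series" means these few. Any claim that something is new, unique, unknown or untested is made for them only; others in the source may bear on it.

Compound 1 `CCOC(=O)Cc1nc(N)n(C(=O)c2ccccc2)n1` and compound 2 `CCOC(=O)Cc1nc(N)n(C(=O)c2ccc(OC)cc2)n1` share one core and differ only by a methoxy in place of hydrogen on an aromatic carbon. In a functional assay on the whole organism (strain albino) for inhibition, with Rattus norvegicus as the target, read by paw edema, with stated times of 30 min and 3 h, at a dose of 5 mg/kg by the oral route (on this read-out lower numbers stand for less inhibition and higher numbers for more inhibition at the one dose given (going by the name of the read-out)), compound 1 gives 57.5%, and in this assay compound 2 gives 60%; the step of a number 2.5 percentage points higher from compound 1 to compound 2 (within the scatter) leaves the two numbers within the scatter of each other, so neither can be ranked above the other. Compound 3 `CCOC(=O)Cc1nc(N)n(C(=O)c2ccc([N+](=O)[O-])cc2)n1` is obtained from compound 2 by the change (nitro in place of methoxy on an aromatic carbon). For the measured compounds named here, the only measured step concerns the same aromatic carbon and was within the scatter, so nothing measured points to a shift in either direction; a step of a number 2 percentage points lower from compound 2 to compound 3 (within the scatter) is expected, that is, none beyond the scatter. On that basis compound 3 is estimated to give 58% in this assay, with a plausible range from 45% to 71%.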

Compound 3, a percentage reported as inhibition, in the whole organism at one dose (the size of the read-out at that dose, not a potency): 68.2%
Compound 3: middle estimate off by 10.2 percentage points, on the low side; the range from low to high includes it.
By their numbers in this assay, from the lowest: compounds 1, 2 and 3 (each within the scatter of the next, the first and the last beyond it).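

For the compounds shown here, at the aromatic carbon para to a large group, the step of a number 10.7 percentage points higher from compound 1 to compound 3 (beyond the scatter) in this assay is the first to pass the scatter, showing that a substituent at this position can register on this read-out. Nitro and methoxy, however, are not separated, as the step of a number 8.2 percentage points higher from compound 2 to compound 3 (within the scatter) shows, so only the comparison of nitro with hydrogen can be read, and that difference is modest. Nothing available bears on why nitro stands apart from hydrogen here.

The compounds shown leave open whether an amine, a carboxylic acid or a chlorine on the same carbon would fall with nitro or with hydrogen. They also leave open how a longer chain in place of the ethyl of the ester would read in this assay.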